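Carbamoyl Replaced by Methanesulfonamido: What to Expect

The source may report more compounds than this note shows. Statements on the series, on what has been measured and on what is new or still open speak of the compounds shown alone.

Compound 1 `Nc1ccc(O)c2ccncc12`: 19000 nM
Compound 2 `NC(=O)c1ccc(O)c2ccccc12`: 430000 nM

Among the compounds with values here, in a functional assay, with a stated time of 15 min (a higher number here means that more compound is needed for the effect, a lower number that less compound is needed), compound 2 gives 430000 nM, the highest of the two numbers so far. Compound 1 gives 19000 nM, and the gap between the two is beyond the usual scatter. Compound 3 `CS(=O)(=O)Nc1ccc(O)c2ccccc12` differs from compound 2 in a single place: methanesulfonamido in place of carbamoyl on an aromatic carbon. Within the data shown here, no measured pair shows this change, so nothing anchors its size. A small step toward a lower number is expected, a 2.9-fold lower number from compound 2 to compound 3 (0.46 log units; beyond the scatter), roughly at the edge of the scatter. Compound 3 is therefore estimated at 150000 nM, with a range from 40000 nM to 600000 nM.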

Compound 3, half-maximal effective concentration: 18000 nM
Compound 3: the middle estimate sits 8.3-fold (0.92 log units) above what was measured; measured number below the stated range.
By their numbers in this assay, from the lowest: compounds 3 and 1 (each within the scatter of the next); then compound 2.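

In this assay the swap of carbamoyl for methanesulfonamido, para to a hydroxy group, gives a 24-fold lower number from compound 2 to compound 3 (1.38 log units; beyond the scatter) and counts as a large step. This shows that the number is sensitive to which group sits at this position on the shared core. Nothing shown explains the size of this step.

The compounds shown do not reveal which part of methanesulfonamido matters. A longer chain on the sulfur, as in ethanesulfonamido, or a carboxylic acid at the same position would help to separate these possibilities.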